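The source may hold more compounds than are shown below. What is called first, only, known or untested is meant among the compounds shown, and "the series" means these compounds.

Compound 1 `O=S(=O)(c1cccc2ccccc12)c1cccc2oc(N3CCNCC3)nc12` and compound 2 `O=S(=O)(c1cccc2ccccc12)c1cccc2oc(N3CCN(C4CCC4)CC3)nc12` were tested in an assay on HeLa cells for displacement of a labelled ligand from 5-hydroxytryptamine receptor 6 (Homo sapiens); a lower number here means a stronger inhibitor, a higher number a weaker inhibitor. Among the measured compounds shown here, compound 1 gives 3.1 nM, and compound 2 gives 72 nM, the higher of the two numbers; the only step, a 23-fold higher number from compound 1 to compound 2 (1.37 log units; beyond the scatter), came from putting cyclobutyl in place of hydrogen on the ring nitrogen. Compound 3 `O=S(=O)(c1cccc2ccccc12)c1cccc2oc(N3CCN(C4CCCC4)CC3)nc12` differs from compound 2 by cyclopentyl in place of cyclobutyl on an amine nitrogen in a ring. For the measured compounds named here, no measured step covers this change; the step from compound 1 to compound 2 only shows that substitution on this nitrogen matters. A small step is expected, a 1.4-fold higher number from compound 2 to compound 3 (0.14 log units; within the scatter), within the scatter. Compound 3 is therefore estimated at 100 nM, between 30 nM and 400 nM.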

Compound 3, inhibition constant: 79 nM
The estimate for compound 3 lay 1.3-fold (0.10 log units) above the measured number; low and high end bracket the measured number.
By their numbers in this assay, from the lowest: compound 1; then compounds 2 and 3 (each within the scatter of the next).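

In this assay the swap of cyclobutyl for cyclopentyl on the amine nitrogen gives no change that can be told from scatter (a 1.1-fold higher number from compound 2 to compound 3 (0.04 log units; within the scatter)), so these two ring sizes are not distinguished at this position. Cyclopentyl in place of the hydrogen also gives a large step (a 25-fold higher number from compound 1 to compound 3 (1.41 log units; beyond the scatter)), so the large step is not limited to cyclobutyl. No supporting measurement explains this result. Still open, on these data alone, is whether a smaller group such as methyl, or a chain ending in a hydroxyl or an amine, would bring the number closer to that of compound 1.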